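Series notes: aryl substituent swap on the shared core

The source may hold more compounds than are shown below. What is called first, only, known or untested is meant among the compounds shown, and "the series" means these compounds.

Measured compounds:
compound 1 `COc1cc2c(Oc3ccc(NC(=O)c4nn(-c5ccccc5C)c(=O)cc4C)cc3F)ccnc2cc1OCCCN1CCC(C)CC1` gives 1290 nM
compound 2 `COc1cc2c(Oc3ccc(NC(=O)c4nn(-c5ccccc5C(F)(F)F)c(=O)cc4C)cc3F)ccnc2cc1OCCCN1CCC(C)CC1` gives 60 nM
compound 3 `COc1ccc(-n2nc(C(=O)Nc3ccc(Oc4ccnc5cc(OCCCN6CCC(C)CC6)c(OC)cc45)c(F)c3)c(C)cc2=O)cc1` gives 400 nM

All three values come from a functional assay on MKN-45 cells (Homo sapiens) for inhibition, read by MTT assay, with a stated time of 72 h; a higher number here means a weaker inhibitor, a lower number a stronger inhibitor. Compound 3 stands second highest of the three numbers there: compound 1 sits at a 3.2-fold lower number from compound 1 to compound 3 (0.51 log units; beyond the scatter) above it, compound 2 at a 6.7-fold higher number from compound 2 to compound 3 (0.82 log units; beyond the scatter) below it. Compound 4 `COc1cc2c(Oc3ccc(NC(=O)c4nn(-c5ccc(Cl)cc5)c(=O)cc4C)cc3F)ccnc2cc1OCCCN1CCC(C)CC1` differs from compound 3 by chloro in place of methoxy on an aromatic carbon. Within the data shown here, no measured step touches this position: the large step of a 22-fold lower number from compound 1 to compound 2 (1.33 log units; beyond the scatter) and the modest steps of a 3.2-fold lower number from compound 1 to compound 3 (0.51 log units; beyond the scatter) and a 6.7-fold higher number from compound 2 to compound 3 (0.82 log units; beyond the scatter) all concern a different part of the aryl ring, so they only set the range the series spans. A step within the scatter, in either direction, is therefore the expectation. Compound 4 is estimated at 300 nM in this assay, expected range 100 nM to 1000 nM, corresponding to an expected step of a 1.3-fold lower number from compound 3 to compound 4 (0.12 log units; within the scatter).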

Compound 4, half-maximal inhibitory concentration: 150 nM
For compound 4 the middle estimate is 2.0-fold (0.30 log units) above the measured one, within the range that was stated.
By their numbers in this assay, from the lowest: compound 2; then compound 4; then compound 3; then compound 1.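

Chloro in place of methoxy on the aromatic carbon para to a large group moves the number beyond the scatter (a 2.7-fold lower number from compound 3 to compound 4 (0.43 log units; beyond the scatter)), so this carbon matters in this assay and not only the aryl substituents already compared. The 4-chlorophenyl group still falls short of 2-(trifluoromethyl)phenyl (a 2.5-fold higher number from compound 2 to compound 4 (0.40 log units; beyond the scatter)) but clearly improves on 2-methylphenyl (an 8.6-fold lower number from compound 1 to compound 4 (0.93 log units; beyond the scatter)). No available evidence accounts for these steps.

Open, going by these compounds, is whether chloro itself matters or any replacement of methoxy would serve; a nitrile or an amine on this carbon would test that.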